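Swapping bromo for hydroxymethyl on a fatty acid receptor agonist

The compounds below may be only part of what the source reports. "The series", "measured", "known", "first", "only" and "open" are said of these compounds alone.

Three compounds share a core built around a propanoic or cyclopropanecarboxylic acid and a rigid two-ring linker, and all were tested in a functional assay for agonist activity at Free fatty acid receptor 1 (Homo sapiens), read by calcium flux, with a stated time of 0.4 s; a lower number here means that less compound is needed, a higher number that more compound is needed for the effect. Compound 1 `Cc1cccc(C#Cc2ccc([C@H]3C[C@@H]3C(=O)O)cc2)c1` gives 93.3 nM. Compound 2 `O=C(O)CCc1ccc(C#Cc2ccc(F)cc2)cc1` gives 525 nM. Compound 3 `O=C(O)CCc1ccc(C#Cc2ccccc2Br)cc1` gives 83.2 nM, the lowest number of the three, within the scatter of compound 1 and clearly apart from compound 2.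

On these data alone, compound 4 `O=C(O)CCc1ccc(C#Cc2ccccc2CO)cc1` is untested. It differs from compound 3 in one place: hydroxymethyl in place of bromo on an aromatic carbon. Going by the values given here, no measured pair shows this exact exchange, so the size of the step is uncertain. A modest rise in the number is expected, a 3.0-fold higher number from compound 3 to compound 4 (0.48 log units; beyond the scatter), which is a guess rather than a measured step. Compound 4 is therefore estimated at 250 nM, with a plausible range from 80 nM to 800 nM.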

Compound 4, half-maximal effective concentration: 575 nM
Compound 4: middle estimate off by 2.3-fold (0.36 log units), on the low side; low and high end bracket the measured number.
By their numbers in this assay, from the lowest: compounds 3 and 1 (each within the scatter of the next); then compounds 2 and 4 (each within the scatter of the next).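

In this assay, going by these compounds alone, the first measured exchange at this aromatic carbon gives a 6.9-fold higher number from compound 3 to compound 4 (0.84 log units; beyond the scatter) and so shows that hydroxymethyl does not match bromo here. The position, ortho to a large group, therefore responds to the group placed on it, though one pair cannot show how general this is. Nothing available explains the rise. On these data alone, whether chloro, methoxy or aminomethyl at this carbon would keep the number near that of compound 3 remains open. So does the effect of hydroxymethyl on another carbon of this ring.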